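Replacing the side chain of compound 3

The source may hold more compounds than are shown below. What is called first, only, known or untested is meant among the compounds shown, and "the series" means these compounds.

In an ADME assay for permeability, using PAMPA, with a stated time of 4 h, at pH 5.5 (a higher number here means that the compound crosses the layer faster, a lower number that the compound crosses the layer more slowly), compound 1 `NCCCCN(C[C@H]1Cc2nccnc2CN1)[C@H]1CCCc2cccnc21` gives 2 nm/s and compound 3 `NC/C=C/CN(C[C@H]1Cc2ncccc2CN1)[C@H]1CCCc2cccnc21` gives 2 nm/s at the bottom of the three numbers, while compound 2 `CN(C[C@@H]1Cc2ncccc2CN1)[C@H]1CCCc2cccnc21` gives 230 nm/s on the far side of the scatter. Compound 3 thus stands level with compound 1, and well short of compound 2.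

Compound 4 `CCN(CC)CCCCN(C[C@H]1Cc2ncccc2CN1)[C@H]1CCCc2cccnc21` differs from compound 3 in one place (3-(diethylamino)propyl in place of 3-aminoprop-1-en-1-yl on a saturated chain carbon bound to an amine nitrogen), with 3-(diethylamino)propyl in place of 3-aminoprop-1-en-1-yl on a saturated chain carbon bound to an amine nitrogen. For the measured compounds named here, no measured pair differs in one place only, so the series offers no direct guide to the size of this step. Compound 4 still ends in an amine, as compound 1 (2 nm/s) and compound 3 (2 nm/s) do, whereas compound 2 (230 nm/s) has no such chain. A small rise in this assay is therefore expected, perhaps none beyond the scatter, and the estimated change is a 2.0-fold higher number from compound 3 to compound 4 (0.30 log units; within the scatter) at most modest. The estimate for compound 4 is 4 nm/s as the expected value, with 1 nm/s to 30 nm/s as its expected range.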

Compound 4, apparent permeability: 3 nm/s
The estimate for compound 4 lay 1.3-fold (0.12 log units) above the measured number; the range from low to high includes it.
By their numbers in this assay, from the lowest: compounds 1, 3 and 4 (each within the scatter of the next); then compound 2.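

In this assay, for the compounds shown here, 3-(diethylamino)propyl in place of 3-aminoprop-1-en-1-yl on a saturated chain carbon bound to an amine nitrogen gives a 1.5-fold higher number from compound 3 to compound 4 (0.18 log units; within the scatter) and so leaves the two compounds level, in the first comparison that differs in one place only. At this position, a group of 8 heavy atoms with 0 hydrogen-bond donors and a group of 4 heavy atoms with 1 hydrogen-bond donor and a double bond thus cannot be told apart by this read-out. No measured evidence bears on why this is so.

Going by these compounds, the step changes the double bond and the two ethyl groups together, so what each does alone remains open. Also open, on these data alone, is whether a chain ending in a carboxylic acid or a hydroxyl group at this position would give a step beyond the scatter.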